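A few compounds are considered here, and "the series" means these few. Any claim that something is new, unique, unknown or untested is made for them only; others in the source may bear on it.

Measured compounds:
compound 1, `CCN(C/C=C/C#CC(C)(C)C)Cc1cccc(OCCN(C)S(=O)(=O)c2ccsc2)c1`, gives 250 nM in a functional assay on HepG2 cells for inhibition of squalene monooxygenase (Homo sapiens); a higher number here means a weaker inhibitor, a lower number a stronger inhibitor.
compound 2, `CCN(C/C=C/C#CC(C)(C)C)Cc1cccc(OCCN(C)S(=O)(=O)c2ccc(C#N)cc2)c1`, gives 200 nM in this assay.
compound 3, `CCN(C/C=C/C#CC(C)(C)C)Cc1cccc(OCCN(C)S(=O)(=O)c2cc3ccccc3s2)c1`, gives 1800 nM in this assay.

Compound 1 stands second highest of the three numbers; compound 2 sits within the scatter of it (a 1.3-fold lower number from compound 1 to compound 2 (0.10 log units; within the scatter)), while compound 3 lies beyond it (a 7.2-fold higher number from compound 1 to compound 3 (0.86 log units; beyond the scatter)). Compound 4, `CCN(C/C=C/C#CC(C)(C)C)Cc1cccc(OCCN(C)S(=O)(=O)c2ccc(Br)s2)c1`, is not yet measured and differs from compound 1 in one place: 5-bromothiophen-2-yl in place of thiophen-3-yl on a sulfonyl sulfur. Both measured steps exchange the group on the sulfonyl sulfur: the 4-cyanophenyl exchange a 1.3-fold lower number from compound 1 to compound 2 (0.10 log units; within the scatter) stayed within the scatter, whereas the 1-benzothiophen-2-yl exchange a 7.2-fold higher number from compound 1 to compound 3 (0.86 log units; beyond the scatter) raised the number modestly. The 5-bromothiophen-2-yl group lies between those two cases, so a small rise is expected, a 1.8-fold higher number from compound 1 to compound 4 (0.26 log units; within the scatter). Compound 4 is therefore estimated at 450 nM, with a range of 200 nM to 1100 nM.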

Compound 4, half-maximal inhibitory concentration: 390 nM
For compound 4 the middle estimate is 1.2-fold (0.06 log units) above the measured one, within the range that was stated.
By their numbers in this assay, from the lowest: compounds 2, 1 and 4 (each within the scatter of the next); then compound 3.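

At the sulfonyl sulfur, 5-bromothiophen-2-yl stays close to both earlier active groups, with a 1.6-fold higher number from compound 1 to compound 4 (0.19 log units; within the scatter) and a 2.0-fold higher number from compound 2 to compound 4 (0.29 log units; within the scatter), so a thiophene ring can carry bromine here without a resolved loss. The fused 1-benzothiophen-2-yl group remains apart, with a 4.6-fold lower number from compound 3 to compound 4 (0.66 log units; beyond the scatter), so the rise at compound 3 does not extend to every change away from thiophen-3-yl. Nothing available explains these differences.

Unsubstituted thiophen-2-yl would be needed to separate the effect of bromine from that of the ring attachment. From the compounds shown here alone, how a carboxylic acid or an amine on the ring would behave at this position remains open.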